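The source may hold more compounds than are shown below. What is called first, only, known or untested is meant among the compounds shown, and "the series" means these compounds.

In an ADME assay on microsomes from liver (Rattus norvegicus) for metabolic stability, read by LC-MS, using NADPH, with a stated time of 30 min, tested at 1 uM (a lower number here means slower removal, a higher number faster removal of the compound), compound 1 (`CC(C)c1noc(N2CCC(Oc3cc(N4CCc5cc(N6CCCNS6(=O)=O)ccc54)ncn3)CC2)n1`) gives 21 mL.min-1.g-1, the middle of three measured numbers. Compound 2 (`CC(C)c1noc(N2CCC(Oc3cc(N4CCc5cc(N6CCCS6(=O)=O)ccc54)ncn3)CC2)n1`) gives 1 mL.min-1.g-1, and compound 3 (`CC(C)c1noc(N2CCC(Oc3cc(N4CCc5cc(N6CCCC6=O)ccc54)ncn3)CC2)n1`) gives 138 mL.min-1.g-1. The next compound to consider is compound 4 (`CC(C)c1noc(N2CCC(Oc3cc(N4CCc5cc(N6CCC(O)CC6=O)ccc54)ncn3)CC2)n1`), which differs from compound 1 in one place: a group of 8 heavy atoms (5 carbon, 1 nitrogen, 2 oxygen; one six-membered non-aromatic ring with 1 hetero atom) in place of a group of 8 heavy atoms (3 carbon, 2 nitrogen, 2 oxygen, 1 sulfur; one six-membered non-aromatic ring with 3 hetero atoms), on an aromatic carbon. The entering group is 4-hydroxy-2-oxopiperidin-1-yl.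

All three measured steps involve this same position, and all are beyond the scatter. The change there gave a 21-fold lower number from compound 1 to compound 2 (1.32 log units; beyond the scatter), a large step, and a 140-fold higher number from compound 2 to compound 3 (2.14 log units; beyond the scatter), also large. The closest guide is a 6.6-fold higher number from compound 1 to compound 3 (0.82 log units; beyond the scatter), a modest step, as the group in compound 3 also has one hetero atom in its ring and no sulfur. Among the measured compounds shown here, no measured compound carries the group in compound 4, so that guide is only partial. A modest rise is therefore expected, with the estimated step being a 2.1-fold higher number from compound 1 to compound 4 (0.33 log units; beyond the scatter). Compound 4 is estimated at 45 mL.min-1.g-1, with an expected range from 12 mL.min-1.g-1 to 150 mL.min-1.g-1.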

Compound 4, intrinsic clearance in microsomes: 13 mL.min-1.g-1
For compound 4 the middle estimate is 3.5-fold (0.54 log units) above the measured one, within the range that was stated.
By their numbers in this assay, from the lowest: compound 2; then compounds 4 and 1 (each within the scatter of the next); then compound 3.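

Putting a group without sulfur, 4-hydroxy-2-oxopiperidin-1-yl, at this position gives a 1.6-fold lower number from compound 1 to compound 4 (0.21 log units; within the scatter), so in this assay the sulfur of compound 1 can be replaced without a change beyond the scatter. A group without sulfur therefore need not give a number as high as that of compound 3: 4-hydroxy-2-oxopiperidin-1-yl in place of 2-oxopyrrolidin-1-yl gives an 11-fold lower number from compound 3 to compound 4 (1.03 log units; beyond the scatter). Compound 2 still stands apart, with a 13-fold higher number from compound 2 to compound 4 (1.11 log units; beyond the scatter).

There is no evidence here to explain these differences. On these data alone, the step from compound 3 to compound 4 enlarges the ring and adds a hydroxyl together, so the share of each stays open; the plain 2-oxopiperidin-1-yl group, without the hydroxyl, would be needed to separate them.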